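One Added Methyl on Compound 2

The source may report more compounds than this note shows. Statements on the series, on what has been measured and on what is new or still open speak of the compounds shown alone.

Compound 1 `Cc1cc(C)c2c(O)cc(-c3cccc4ccccc34)nc2n1` gives 9550 nM
Compound 2 `Cc1ccnc2nc(-c3ccc4ccccc4c3)cc(O)c12` gives 2400 nM

In a functional assay on CAKI-1 cells (Homo sapiens) for antiproliferative activity (on this read-out higher numbers stand for weaker inhibition of growth and lower numbers for stronger inhibition of growth), compound 2 stands lowest at 2400 nM and so inhibits growth more strongly than compound 1 at 9550 nM by a margin beyond the scatter. That gap is the only spread seen so far, and it says nothing direct about the change considered here.

Compound 3 (`Cc1cc(C)c2c(O)cc(-c3ccc4ccccc4c3)nc2n1`) is compound 2 with one alteration (methyl in place of hydrogen on an aromatic carbon): methyl in place of hydrogen on an aromatic carbon, next to the ring nitrogen. Within the data shown here, no measured pair shows what this change does on its own, so the expectation rests on compound 2 at 2400 nM alone. A slight weakening of growth inhibition is expected, with the estimated step (a 1.3-fold higher number from compound 2 to compound 3 (0.10 log units; within the scatter)) staying within the scatter. For compound 3 the estimated value is 3000 nM with an expected range from 1000 nM to 9000 nM in repeated measurements.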

Compound 3, concentration for 50% growth inhibition: 51300 nM
Compound 3: middle estimate off by 17-fold (1.23 log units), on the low side; the whole stated range lies below it.
By their numbers in this assay, from the lowest: compound 2; then compound 1; then compound 3.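

In this assay, methyl in place of hydrogen on this aromatic carbon, next to the ring nitrogen, gives a 21-fold higher number from compound 2 to compound 3 (1.33 log units; beyond the scatter), a large weakening of growth inhibition. Among these compounds, this is the first measured pair that differs in one place, and it shows that this position is far from indifferent: one added carbon, with no hydrogen-bond donors or acceptors and no net charge, is enough to produce a step of this size. Nothing available here explains the step.

Whether any substituent on this carbon would do the same, or whether the loss is particular to methyl, stays open, since a fluorine atom, a methoxy group or an amine at this place is not among the compounds shown. A single pair also cannot say whether the step would hold on other cell lines or with other changes elsewhere on the core.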